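The compounds below may be only part of what the source reports. "The series", "measured", "known", "first", "only" and "open" are said of these compounds alone.

Working notes on the series, three compounds measured in an assay on isolated protein for inhibition of Dihydrofolate reductase (Mus musculus); a lower number here means a less potent compound, a higher number a more potent compound, by a factor of ten per unit of this negative logarithm. Compound 1, structure `CC1(C)N=C(N)N=C(N)N1c1ccc(OCc2cc(S(=O)(=O)F)ccc2Cl)c(Cl)c1`, gives 7.38. Compound 2, structure `CC1(C)N=C(N)N=C(N)N1c1ccc(OCc2ccc(S(=O)(=O)F)cc2)c(Cl)c1`, gives 7.58, which sits within the scatter of the number for compound 1. Within the data shown here, compound 3, structure `CC1(C)N=C(N)N=C(N)N1c1cccc(OCCOc2ccc(S(=O)(=O)F)cc2)c1`, gives 7.82, a number beyond the scatter above that of compound 1, so compound 1 holds the lowest of the three numbers measured so far, though only its gap to compound 3 counts as a real difference.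

Compound 4, structure `CC1(C)N=C(N)N=C(N)N1c1ccc(OCc2cccc(S(=O)(=O)F)c2)c(Cl)c1`, has not yet been measured in this assay. Set against compound 1 it differs in one place: hydrogen in place of chloro on an aromatic carbon. Among the measured compounds shown here, no pair of measured compounds that differ in a single place is available, so the size of this step cannot be read from a measured precedent. The change removes one chlorine and nothing else, and nothing measured here indicates the direction. For compound 4 the expectation is a number close to that of compound 1, with the step of a number 0.02 log units higher from compound 1 to compound 4 (within the scatter) expected to stay within the usual scatter in either direction. Compound 4 is accordingly estimated at 7.4 in this assay, with a range from 6.9 to 7.9.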

Compound 4, logarithm of the reciprocal of the active concentration, log(1/C): 7.72
Beside the measured number, compound 4's estimate is 0.32 log units below it; low and high end bracket the measured number.
By their numbers in this assay, from the lowest: compounds 1, 2, 4 and 3 (each within the scatter of the next, the first and the last beyond it).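

Among these compounds, the pair gives the series its only single-place step. In this assay, hydrogen in place of chloro on the aromatic carbon ortho to a large group and para to a fluorosulfonyl group gives a number 0.34 log units higher from compound 1 to compound 4 (beyond the scatter), so this position responds to the change, and the number does not depend on chloro being there. No measurement at hand accounts for the step, and its size and direction are all that can be said of this position.

A single step at a single position cannot show where other groups would fall relative to chloro and hydrogen, such as fluoro, methyl, methoxy or an amine on the same aromatic carbon. Also open, from the compounds shown here alone, is whether replacing the remaining chloro group of compound 4 with hydrogen would move the number in the same direction, and whether a step of this size would recur with the fluorosulfonyl group elsewhere on the ring.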